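The source may report more compounds than this note shows. Statements on the series, on what has been measured and on what is new or still open speak of the compounds shown alone.

Of the compounds shown here, two carrying the same core have been measured in a functional assay on MDA-MB-231 cells (Homo sapiens) for cytotoxicity, read by MTT assay, with a stated time of 72 h; a lower number here means a stronger inhibitor, a higher number a weaker inhibitor. Compound 1 `COc1cc2c(Oc3ccc(NC(=O)c4nn(-c5ccc(Br)cc5)c(=O)c5ccccc45)cc3F)ccnc2cc1OCCCN1CCCCC1` bears a 4-bromophenyl on the ring nitrogen and a plain piperidine at the end of the side chain; in this assay compound 1 gives 1130 nM. Compound 2 `COc1cc2c(Oc3ccc(NC(=O)c4nn(-c5cccc(F)c5)c(=O)c5ccccc45)cc3F)ccnc2cc1OCCCN1CCC(C)CC1` instead carries a 3-fluorophenyl on the ring nitrogen and a 4-methylpiperidine on the chain; in this assay compound 2 gives 860 nM. Compound 2 thus stands beside compound 1, the two numbers lying within the scatter of each other, so no ranking between them can be drawn.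

Compound 3 `COc1cc2c(Oc3ccc(NC(=O)c4nn(-c5ccc(Br)cc5)c(=O)c5ccccc45)cc3F)ccnc2cc1OCCCN1CCC(C)CC1` is derived from compound 2 by one change: 4-bromophenyl in place of 3-fluorophenyl on an aromatic nitrogen. Within the data shown here, no measured pair in this set isolates this exchange, so there is no step to lean on. Given that compound 1, which also carries the 4-bromophenyl, gives 1130 nM, compound 3 is expected to land close to compound 2, with a 1.2-fold higher number from compound 2 to compound 3 (0.07 log units; within the scatter) as the estimated step and no shift beyond the scatter. In this assay compound 3 is estimated at 1000 nM, within a range of 450 nM to 2300 nM.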

Compound 3, half-maximal inhibitory concentration: 1160 nM
For compound 3 the middle estimate is 1.2-fold (0.06 log units) below the measured one; low and high end bracket the measured number.
By their numbers in this assay, from the lowest: compounds 2, 1 and 3 (each within the scatter of the next).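

In this assay, 4-bromophenyl in place of 3-fluorophenyl on the aromatic nitrogen gives a 1.3-fold higher number from compound 2 to compound 3 (0.13 log units; within the scatter), so the two aryl groups cannot be told apart at this position when the chain ends in 4-methylpiperidine. Methyl in place of hydrogen on a saturated ring carbon, the one difference between the plain piperidine and the 4-methylpiperidine, gives a 1.0-fold higher number from compound 1 to compound 3 (0.01 log units; within the scatter), so with 4-bromophenyl on the nitrogen this change also stays within the noise of the measurement. Nothing at hand speaks to the reason for either result.

From the compounds shown here alone, both groups seen on the aromatic nitrogen are halogen-bearing phenyl rings, so it remains open how an unsubstituted phenyl, a 4-methoxyphenyl or a simple methyl would read at that position. At the end of the side chain only piperidine and 4-methylpiperidine are shown, which leaves open what a morpholine, a piperazine or a dimethylamine would give there, and whether a shorter or longer chain would separate from these compounds at all.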